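The source may hold more compounds than are shown below. What is called first, only, known or untested is meant among the compounds shown, and "the series" means these compounds.

Measured in a functional assay on Vero cells (Chlorocebus sabaeus) for inhibition; a higher number here means a weaker inhibitor, a lower number a stronger inhibitor:
- compound 1 `CSc1ccc(Cn2cnc3c(-c4ccco4)ncnc32)cc1`: 6.9 ug/mL
- compound 2 `COc1cccc(Cn2cnc3c(-c4ccco4)ncnc32)c1`: > 625 ug/mL

The entry for compound 2 is a limit of the assay and not a number. For the measured compounds named here, that leaves compound 1 with the only true number in this assay, so it has no numerical comparison. Compound 3 `CCOc1ccc(Cn2cnc3c(-c4ccco4)ncnc32)cc1` changes one group of compound 1: ethoxy in place of methylsulfanyl on an aromatic carbon, with ethoxy in place of methylsulfanyl on an aromatic carbon. Going by the values given here, no measured pair shows the effect of such a swap, so any forecast is uncertain. Expected is a 2.2-fold higher number from compound 1 to compound 3 (0.34 log units; beyond the scatter), a modest move toward weaker inhibition. Compound 3 is estimated at 15 ug/mL, with an expected range of 3 ug/mL to 100 ug/mL.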

Compound 3, half-maximal inhibitory concentration: 37.4 ug/mL
Beside the measured number, compound 3's estimate is 2.5-fold (0.40 log units) below it; measured number inside the range.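

In this assay, the swap of methylsulfanyl for ethoxy, on an aromatic carbon para to a large group, gives a 5.4-fold higher number from compound 1 to compound 3 (0.73 log units; beyond the scatter). Inhibition weakens, yet compound 3 still gives a true number and not a limit, so this position accepts the change at some cost. Nothing measured here explains the step.

Sulfur gives way to oxygen and the chain grows in the same change, so which of the two carries the step stays open. Going by these compounds, how an amine or a carboxylic acid would read out at this position is also open.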